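Oxazolidinone side-chain swaps and solubility

A few compounds are considered here, and "the series" means these few. Any claim that something is new, unique, unknown or untested is made for them only; others in the source may bear on it.

Compound 1 `CCN1CCN(C[C@H]2CN(c3ccc(-n4cc(-c5ccccn5)cn4)c(F)c3)C(=O)O2)CC1` is the highest of the three measured in a physicochemical assay for solubility, read by HPLC, with a stated time of 24 h (on this read-out higher numbers stand for higher solubility and lower numbers for lower solubility), where compound 1 gives 706000 nM. Compound 3 `CN(C)S(=O)(=O)NC[C@H]1CN(c2ccc(-n3cc(-c4ccccn4)cn3)c(F)c2)C(=O)O1` gives 472000 nM, and compound 2 `COC[C@H]1CN(c2ccc(-n3cc(-c4ccccn4)cn3)c(F)c2)C(=O)O1` gives 36200 nM. Compound 4 `CONC(=O)[C@H]1CN(c2ccc(-n3cc(-c4ccccn4)cn3)c(F)c2)C(=O)O1` differs from compound 1 by methoxycarbamoyl in place of (4-ethylpiperazin-1-yl)methyl on a saturated ring carbon. Going by the values given here, two measured steps bear on it: a 20-fold lower number from compound 1 to compound 2 (1.29 log units; beyond the scatter) and a 1.5-fold lower number from compound 1 to compound 3 (0.17 log units; within the scatter), both replacing the same group on the side chain. Removing the 4-ethylpiperazin-1-yl gave either a large drop or no change beyond the scatter, so a drop in this assay is expected for compound 4, smaller than that to compound 2, estimated as a 5.9-fold lower number from compound 1 to compound 4 (0.77 log units; beyond the scatter). Compound 4 is expected to give 120000 nM, with a range of 25000 nM to 400000 nM.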

Compound 4, solubility: 78100 nM
Estimate against measurement, compound 4: 1.5-fold (0.19 log units) above; measured number inside the range.
By their numbers in this assay, from the lowest: compound 2; then compound 4; then compounds 3 and 1 (each within the scatter of the next).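

Methoxycarbamoyl on the saturated ring carbon places compound 4 within the range of the side chains: a 9.0-fold lower number from compound 1 to compound 4 (0.96 log units; beyond the scatter) and a 6.0-fold lower number from compound 3 to compound 4 (0.78 log units; beyond the scatter), yet a 2.2-fold higher number from compound 2 to compound 4 (0.33 log units; beyond the scatter). In this assay, this position therefore carries a group with a carbonyl and one hydrogen-bond donor without falling to the level of compound 2. No measurement available here accounts for this order.

From the compounds shown here alone, whether the carbonyl on the ring carbon or the methoxy end sets the order stays open. A primary carboxamide or a carboxylic acid on that saturated ring carbon would separate the two.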